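Swapping the aryl group on a chalcone-lactone hybrid

A few compounds are considered here, and "the series" means these few. Any claim that something is new, unique, unknown or untested is made for them only; others in the source may bear on it.

Compound 1 `CC(C)(C)c1ccc(/C=C/C(=O)c2ccc(OCC(=O)N[C@H]3CCOC3=O)cc2)cc1` carries a 4-(tert-butyl)phenyl group on its chalcone double bond. Among the compounds with values here, in a functional assay on MGC-803 cells (Homo sapiens) for antiproliferative activity, read by MTT assay, with a stated time of 72 h (a higher number here means a weaker inhibitor, a lower number a stronger inhibitor), compound 1 gives 17200 nM, the only numerical value recorded among the three measured compounds. Compound 2 `O=C(CNc1cccc(Cl)c1)N[C@H]1CCOC1=O` reaches only the limit of > 64000 nM in this assay. Compound 3 `O=C(CNc1ccc(Br)cc1)N[C@H]1CCOC1=O` likewise stops at the limit of > 64000 nM. Two of three results therefore rest at the limit of > 64000 nM in this assay, at which 2 of the 3 values shown sit.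

Compound 4 `O=C(COc1ccc(C(=O)/C=C/c2ccc(Cl)cc2Cl)cc1)N[C@H]1CCOC1=O` differs from compound 1 in one place: 2,4-dichlorophenyl in place of 4-(tert-butyl)phenyl on a double-bonded chain carbon bound to a double-bonded chain carbon. Within the data shown here, no measured pair with a single change is available to guide the size of this step, so only a modest movement, within or near the scatter, is expected, a 1.4-fold lower number from compound 1 to compound 4 (0.16 log units; within the scatter). Compound 4 is estimated at 12000 nM, between 4000 nM and 40000 nM.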

Compound 4, half-maximal inhibitory concentration: 26500 nM
Compound 4: middle estimate off by 2.2-fold (0.34 log units), on the low side, within the range that was stated.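

Within the data shown here, the first single-change pair at this position, on a double-bonded chain carbon bound to a double-bonded chain carbon, gives a 1.5-fold higher number from compound 1 to compound 4 (0.19 log units; within the scatter) in this assay. Exchanging 4-(tert-butyl)phenyl for 2,4-dichlorophenyl, two groups with different atoms on the ring, therefore leaves the read-out within its usual scatter. Nothing measured here explains why the two groups read alike. Still open, going by these compounds, is what a phenyl group carrying an amine or a carboxylic acid would give in this place. Also open, on these data alone, is whether any group here can move the number beyond the scatter.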